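Removing a methylene linker ahead of a cytotoxicity read-out

The source may report more compounds than this note shows. Statements on the series, on what has been measured and on what is new or still open speak of the compounds shown alone.

Compound 1 `CN1CCN(Cc2ccc(Nc3nc(Oc4ccc5ccc(=O)[nH]c5c4)c4sccc4n3)cc2)CC1` was examined in an ADME assay on L02 cells (Homo sapiens) for cytotoxicity, read by MTT assay, with a stated time of 72 h (on this read-out lower numbers stand for stronger inhibition and higher numbers for weaker inhibition), where compound 1 gives 7990 nM. Going by the values given here, this is the only actual number in the set: the one other value is a limit of the assay. Compound 2 `CCN1CCN(c2nc(Oc3ccc4ccc(=O)[nH]c4c3)c3sccc3n2)CC1` in this assay reaches only the limit of > 20000 nM. Where compound 1 stands can therefore be said only against that limit (the limit of > 20000 nM in this assay, at which 1 of the 2 values shown sits), with compound 1 the sole compound for which a number was obtained.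

Compound 3 `CN1CCN(c2ccc(Nc3nc(Oc4ccc5ccc(=O)[nH]c5c4)c4sccc4n3)cc2)CC1` differs from compound 1 in one place: 4-methylpiperazin-1-yl in place of (4-methylpiperazin-1-yl)methyl on an aromatic carbon. Among the compounds with values here, no pair of measured compounds shows the effect of this change, so no measured step can be pointed to. The account expects the step from compound 1 to compound 3 to stay within the usual scatter, with no clear direction, so that a 1.0-fold higher number from compound 1 to compound 3 (0.00 log units; within the scatter) is the anticipated shift. Compound 3 is accordingly estimated at 8000 nM in this assay, within a range from 3000 nM to 20000 nM.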

Compound 3, half-maximal inhibitory concentration: > 50000 nM
Compound 3: no number, only a limit; the forecaster's own chance of this, stated with the estimate: 25%; middle value at least 6.2-fold (0.79 log units) from the limit.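

Removing the methylene linker, with 4-methylpiperazin-1-yl in place of (4-methylpiperazin-1-yl)methyl on an aromatic carbon para to a large group, gives an at least 6.2-fold higher number from compound 1 to compound 3 (0.79 log units; beyond the scatter) in this assay. Going by these compounds alone, this is the first single-place comparison in the set, and it shows that this position is sensitive to the linker: one methylene fewer, with the rest of the structure unchanged, takes the result from a measured number to a limit, whereas compound 1 and compound 2 differ in more than one place and could not isolate any such change. The value of compound 3 is a limit and not a number, so the true size of the step remains open on its upper side: the limit of > 50000 nM in this assay, at which 1 of the 3 values shown sits.

What the compounds shown leave open is whether the shift follows the length of the link alone or also depends on the amine carried on it. A longer chain, such as an ethylene link to the same piperazine, or a morpholine on the methylene link of compound 1, would help to separate these two possibilities.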